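Swapping a Branched Chain for a Small Carbon Ring

The source may hold more compounds than are shown below. What is called first, only, known or untested is meant among the compounds shown, and "the series" means these compounds.

Compound 3 `CCC(C)OC(=O)C1=C(C)NC(=O)NC1c1ccsc1` was tested in an assay on membranes from CHO cells for displacement of a labelled ligand from adenosine receptor A1 (Homo sapiens), read by scintillation counting, with a stated time of 60 min, tested at 1 uM (a higher number here means more inhibition at the concentration tested (going by the name of the read-out), a lower number less inhibition), where compound 3 gives 5%. Among the three compounds measured this is the second highest number. Compound 2 `CCNC(=O)C1=C(C)NC(=O)NC1c1ccsc1` gives 3%, and a number 2 percentage points higher from compound 2 to compound 3 (within the scatter). Compound 1 `CC1=C(C(=O)OCc2ccccc2)C(c2ccsc2)NC(=O)N1` gives 57%, and a number 52 percentage points lower from compound 1 to compound 3 (beyond the scatter). Compound 4 `CC1=C(C(=O)OC2CCCC2)C(c2ccsc2)NC(=O)N1` is not yet measured; it differs from compound 3 by cyclopentyl in place of sec-butyl on an oxygen next to a carbonyl group. Among the measured compounds shown here, only that large step from compound 1 to compound 3 touches the same place, and it came with loss of benzyl. The entering cyclopentyl has one five-membered non-aromatic ring of carbon only, not an aromatic ring, so the step of a number 5 percentage points higher from compound 3 to compound 4 (within the scatter) is expected to stay within the scatter. Compound 4 is estimated at 10%, between 0% and 30%.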

Compound 4, a percentage reported as inhibition, at one concentration (the size of the read-out at that concentration, not a potency): 5%
Estimate against measurement, compound 4: 5 percentage points above; the range from low to high includes it.
By their numbers in this assay, from the lowest: compounds 2, 3 and 4 (each within the scatter of the next); then compound 1.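

Closing the sec-butyl chain into a cyclopentyl ring gives no change at the digits printed from compound 3 to compound 4 (within the scatter), so a ring of carbon alone, without aromatic character, does not recover the number seen with benzyl. Cyclopentyl in place of benzyl gives a number 52 percentage points lower from compound 1 to compound 4 (beyond the scatter), while cyclopentyloxy in place of ethylamino gives a number 2 percentage points higher from compound 2 to compound 4 (within the scatter) and leaves compound 4 level with the low pair. Nothing at hand explains these numbers.

Still open, from the compounds shown here alone, is whether a phenyl ring alone is enough, or whether a longer chain such as phenylethyl would hold the number seen with benzyl.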